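This account rests on a few compounds, and the source may have more. Where it says the series, first, only, none or still open, it means among the compounds named here.

Compound 2 `CCCCCCCCOc1ccc2c(Cl)ccnc2c1` is the weakest of the three measured compounds in a functional assay on SK-OV-3 cells (Homo sapiens) for cytotoxicity, read by MTT assay, with a stated time of 48 h (on this read-out higher numbers stand for weaker inhibition and lower numbers for stronger inhibition), where compound 2 gives 4300 nM. Compound 1 `CN(C)CCNc1ccnc2cc(OCc3ccc(F)cc3)ccc12` gives 890 nM in this assay, and compound 3 `C=CCOc1ccc2c(NCCN(C)C)ccnc2c1` gives 1560 nM; both numbers lie below that of compound 2 by more than the scatter. Compound 4 `Clc1ccnc2cc(OCCc3ccccc3)ccc12` differs from compound 2 only in the ether chain: phenyl in place of hexyl on a saturated chain carbon, two bonds along the chain from an oxygen on an aromatic ring. Among the measured compounds shown here, the one measured step that bears on swapping an aromatic ring for an open chain on the ether side is that from compound 1 to compound 3, which replaces 4-fluorophenyl with vinyl and gives a 1.8-fold higher number from compound 1 to compound 3 (0.24 log units; within the scatter). For the measured compounds named here, that step stayed within the scatter, and no measured pair speaks to the chlorine-bearing core of compound 2 with an aryl chain, so compound 2 and compound 4 are expected to differ little. The expected step is a 1.4-fold lower number from compound 2 to compound 4 (0.16 log units; within the scatter). Compound 4 is therefore estimated at 3000 nM in this assay, within a range from 1000 nM to 9000 nM.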

Compound 4, half-maximal inhibitory concentration: 2010 nM
Estimate against measurement, compound 4: 1.5-fold (0.17 log units) above; measured number inside the range.
By their numbers in this assay, from the lowest: compounds 1, 3 and 4 (each within the scatter of the next, the first and the last beyond it); then compound 2.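

With the chlorine-bearing core of compound 2, putting phenyl in place of hexyl on a saturated chain carbon, two bonds along the chain from an oxygen on an aromatic ring, gives a 2.1-fold lower number from compound 2 to compound 4 (0.33 log units; beyond the scatter) in this assay, so at this position a ring and an open chain of the same heavy-atom count can be told apart, if only modestly. The earlier ring-to-chain step, a 1.8-fold higher number from compound 1 to compound 3 (0.24 log units; within the scatter), stayed within the scatter, although its direction agrees: in both pairs the compound with the aromatic ring has the lower number. Nothing given here accounts for the difference.

As far as these compounds go, it remains open whether an amine or a carboxylic acid on the phenyl ring, or a longer chain carrying that ring, would shift the number further. Also open, from the compounds shown here alone, is whether the same swap would give a step of similar size on the core of compound 1.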